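The source may hold more compounds than are shown below. What is called first, only, known or untested is meant among the compounds shown, and "the series" means these compounds.

Working notes on the series, measured in a functional assay on A498 cells (Homo sapiens) for cytotoxicity, read by sulforhodamine B assay, with a stated time of 48 h, tested at 1 uM; on this read-out lower numbers stand for a stronger effect and higher numbers for a weaker effect at the one concentration tested.

Compound 1 `COc1cc(-c2cc(/C=C/C(=O)c3ccc(Cl)c(Cl)c3)[nH]n2)cc(OC)c1OC` carries the 3,4-dichlorophenyl on the carbonyl carbon and gives 73% in this assay. Of the three numbers recorded so far it is the second highest. Compound 3 `COc1ccc(-c2cc(/C=C/C(=O)c3cc(OC)c(OC)c(OC)c3)[nH]n2)cc1OC` is the nearest to it, giving 65% in this assay, a value within the scatter of compound 1, so the two cannot be told apart. Compound 2 `COc1ccc(-c2cc(/C=C/C(=O)c3ccc(N)cc3)[nH]n2)cc1OC` is the furthest away, giving 89% in this assay, beyond the scatter and on the weaker side of compound 1.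

Compound 4 `COc1ccc(C(=O)/C=C/c2cc(-c3cc(OC)c(OC)c(OC)c3)n[nH]2)cc1OC` keeps the shared core and the rest of compound 1 and changes only the group on the carbonyl carbon: 3,4-dimethoxyphenyl in place of 3,4-dichlorophenyl on a carbonyl carbon. Among the measured compounds shown here, no measured pair shows this exact exchange, so the size of the step is taken from what the rest shows. Compound 3 carries methoxy groups on the aryl bound to the carbonyl and gives 65% in this assay, close to compound 1, so the exchange in compound 4 is expected to leave the read-out near where compound 1 stands. The expected step is a number 3 percentage points lower from compound 1 to compound 4 (within the scatter), not beyond the scatter, with a slight lean toward a lower number. Compound 4 is therefore estimated at 70% in this assay, between 55% and 85%.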

Compound 4, a percentage reported as activity, at one concentration (the size of the read-out at that concentration, not a potency): 78%
For compound 4 the middle estimate is 8 percentage points below the measured one, and the stated range covers the measured number.
By their numbers in this assay, from the lowest: compounds 3, 1 and 4 (each within the scatter of the next, the first and the last beyond it); then compound 2.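

In this assay, among the compounds shown here, exchanging the 3,4-dichlorophenyl on the carbonyl carbon for 3,4-dimethoxyphenyl gives a number 5 percentage points higher from compound 1 to compound 4 (within the scatter), the first step that can be read between compounds differing in one place. With the rest of the structure held constant, this pair shows that the read-out at this position does not separate the two aryl groups, although one carries two chlorine atoms and the other carries two hydrogen-bond acceptors with oxygen in their place. This is a single exchange at a single concentration, and no measurement available here bears on why the read-out holds across it.

On these data alone, it remains open whether the position on the carbonyl carbon stays as undemanding for groups of a different kind, such as an unsubstituted phenyl, a phenyl bearing a carboxylic acid, or a longer alkyl chain in place of the aryl. As far as these compounds go, it is equally open whether the same exchange would give a similar step on a compound with a different aryl on the other side of the shared core, or at a concentration other than the one used here.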